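Ethoxycarbonyl in place of hydroxymethyl on the chain

The compounds below may be only part of what the source reports. "The series", "measured", "known", "first", "only" and "open" are said of these compounds alone.

In an ADME assay on Vero cells (Chlorocebus sabaeus) for cytotoxicity, read by fluorescence and resazurin assay, with a stated time of 3 days (a lower number here means that less compound is tolerated, a higher number that more compound is tolerated), compound 3 `CC1(C)O[C@H]2O[C@H]([C@H](CCO)n3cnc4c(N)ncnc43)[C@H](Oc3ccccc3[N+](=O)[O-])[C@H]2O1` gives 148000 nM. Compound 1 `CCOC(=O)C[C@H]([C@H]1O[C@@H]2OC(C)(C)O[C@@H]2[C@H]1Oc1ccccc1[N+](=O)[O-])n1cnc2c(N)ncnc21` gives 119000 nM and compound 2 `CCOC(=O)C[C@@H]([C@H]1O[C@@H]2OC(C)(C)O[C@@H]2[C@H]1Oc1ccccc1N)n1cnc2c(N)ncnc21` gives 89700 nM, so both sit within the scatter of compound 3 and the three values do not separate.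

Compound 4 `CCOC(=O)C[C@@H]([C@H]1O[C@@H]2OC(C)(C)O[C@@H]2[C@H]1Oc1ccccc1[N+](=O)[O-])n1cnc2c(N)ncnc21` is still unmeasured. Its structure departs from compound 3 as follows: ethoxycarbonyl in place of hydroxymethyl on a saturated chain carbon, two bonds along the chain from an aromatic nitrogen and a saturated ring carbon. The ethoxycarbonyl replaces hydroxymethyl on a saturated chain carbon, two bonds along the chain from an aromatic nitrogen and a saturated ring carbon.

Among the measured compounds shown here, no measured pair isolates this change, so any expectation rests on thin evidence. Compound 1 also carries ethoxycarbonyl and gives 119000 nM, which does not separate from the value of compound 3. On these data alone, no step beyond the scatter is therefore expected in this assay, and the direction stays open. The expected change is a 1.3-fold lower number from compound 3 to compound 4 (0.13 log units; within the scatter). For compound 4 the estimated value is 110000 nM, with an expected range of 60000 nM to 200000 nM.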

Compound 4, half-maximal cytotoxic concentration: 96300 nM
Compound 4: middle estimate off by 1.1-fold (0.06 log units), on the high side; measured number inside the range.
By their numbers in this assay, from the lowest: compounds 2, 4, 1 and 3 (each within the scatter of the next).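

In this assay, the change from hydroxymethyl to ethoxycarbonyl on the saturated chain carbon now has a pair that isolates it, and that pair gives a 1.5-fold lower number from compound 3 to compound 4 (0.19 log units; within the scatter), so the swap does not separate the two compounds. Nitro in place of amino on an aromatic carbon gives a 1.1-fold higher number from compound 2 to compound 4 (0.03 log units; within the scatter), so this change also leaves the values unseparated. The stereocentre at the saturated chain carbon, drawn R or S, is now tested on its own and gives a 1.2-fold lower number from compound 1 to compound 4 (0.09 log units; within the scatter), a comparison that isolates configuration: the fact that compounds 1 and 4 differ only in the configuration as drawn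

On these data alone, whether a carboxylic acid, an amine or a longer chain at this position would move the number beyond the scatter stays open. The compounds shown also leave open whether any change to the shared core would separate from these values.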